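This account rests on a few compounds, and the source may have more. Where it says the series, first, only, none or still open, it means among the compounds named here.

Three compounds have been measured in a physicochemical assay for pharmacokinetics, read by HPLC, at pH 7.5, tested at 250 uM; on this read-out higher numbers stand for a longer-lived compound and lower numbers for a shorter-lived compound:

Compound 1, `Cc1ccc2c(c1)CC(CN(C)C)C2=O`: 0.4 h
Compound 2, `Cc1ccc2c(c1)C(=O)C(CN(C)C)C2`: 0.233 h
Compound 3, `COc1ccc2c(c1)CC(CN(C)C)C2=O`: 0.75 h

Compound 1 and compound 3 share a core and differ only by methoxy in place of methyl on an aromatic carbon. This change gave a 1.9-fold higher number from compound 1 to compound 3 (0.27 log units; within the scatter), a step that is within the scatter, so the two values cannot be told apart with confidence.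

Compound 2 is built from the same atoms as compound 1, joined differently; the difference between the two cores is not broken down here. Its value in this assay sits within the scatter of compound 1 but beyond the scatter of compound 3.

Compound 4, `COc1ccc2c(c1)C(=O)C(CN(C)C)C2`, has not yet been measured. It stands to compound 2 as compound 3 stands to compound 1: methoxy in place of methyl on an aromatic carbon, the same change at the same place. Within the data shown here, the expected step, a 1.9-fold higher number from compound 2 to compound 4 (0.28 log units; within the scatter), rests on the single earlier instance, a 1.9-fold higher number from compound 1 to compound 3 (0.27 log units; within the scatter), which was within the scatter. On that basis compound 4 is estimated at 0.44 h, with a likely range from 0.25 h to 0.8 h.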

Compound 4, half-life: 0.2 h
Estimate against measurement, compound 4: 2.2-fold (0.34 log units) above; the whole stated range lies above it.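

In this assay, methoxy in place of methyl on an aromatic carbon gave a 1.2-fold lower number from compound 2 to compound 4 (0.07 log units; within the scatter) on the core of compound 2, while on the core of compound 1 it gave a 1.9-fold higher number from compound 1 to compound 3 (0.27 log units; within the scatter). Each step lies within the scatter, so on neither core can the change be told apart from the ordinary spread of repeated measurements; the printed directions are opposite, but that does not show that the change reverses from one core to the other, and two steps this small do not show that it carries across reliably either. No measurement is available that would explain these numbers.

The compounds shown leave open whether a different group on this aromatic carbon, such as ethoxy, an amine or a carboxylic acid, would give a step beyond the scatter on either core. Only such a larger step could test whether a change made on one core carries to the other in this series.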